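Methoxy for Bromo on the Sulfonyl Aryl of Compound 1

The source may report more compounds than this note shows. Statements on the series, on what has been measured and on what is new or still open speak of the compounds shown alone.

Compound 1 `O=S(=O)(NCCCNc1nccc(-c2c(-c3cccc(F)c3)nc3sccn23)n1)c1ccc(Br)cc1` was tested in a functional assay on A-375 cells (Homo sapiens) for cytotoxicity, read by MTT assay (on this read-out higher numbers stand for weaker inhibition and lower numbers for stronger inhibition), and gives 7040 nM. Among the three measured compounds it holds the second highest number: compound 2 `O=C(NCCNc1nccc(-c2c(-c3cccc(F)c3)nc3sccn23)n1)c1ccc(Cl)cc1` gives 2570 nM, a 2.7-fold lower number from compound 1 to compound 2 (0.44 log units; beyond the scatter), while compound 3 `O=S(=O)(NCCNc1nccc(-c2c(-c3cccc(F)c3)nc3sccn23)n1)c1ccc(Cl)cc1` gives 18600 nM, a 2.6-fold higher number from compound 1 to compound 3 (0.42 log units; beyond the scatter). The unmeasured compound 4 `COc1ccc(S(=O)(=O)NCCCNc2nccc(-c3c(-c4cccc(F)c4)nc4sccn34)n2)cc1` differs from compound 1 by methoxy in place of bromo on an aromatic carbon. Going by the values given here, none of the measured steps alters this group alone: a 2.7-fold lower number from compound 1 to compound 2 (0.44 log units; beyond the scatter) and a 2.6-fold higher number from compound 1 to compound 3 (0.42 log units; beyond the scatter) each change the chain and the aryl substituent together, and a 7.2-fold higher number from compound 2 to compound 3 (0.86 log units; beyond the scatter) concerns the sulfonyl against the carbonyl. Among the compounds with values here, with no direct precedent, compound 4 is expected to show a 1.0-fold lower number from compound 1 to compound 4 (0.00 log units; within the scatter), nothing beyond the scatter. Compound 4 is therefore estimated at 7000 nM, within 3000 nM to 17000 nM.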

Compound 4, half-maximal inhibitory concentration: 5510 nM
Estimate against measurement, compound 4: 1.3-fold (0.10 log units) above; measured number inside the range.
By their numbers in this assay, from the lowest: compound 2; then compounds 4 and 1 (each within the scatter of the next); then compound 3.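

Replacing the 4-bromophenyl with a 4-methoxyphenyl while leaving the rest of compound 1 unchanged gives in this assay a 1.3-fold lower number from compound 1 to compound 4 (0.11 log units; within the scatter), so this single change produces no difference beyond the scatter. The earlier steps shown here could not show this, since none of them altered this group alone. Nothing available explains the result. As far as these compounds go, whether an amine or a carboxylic acid at this ring carbon would also leave the number within the scatter remains open, as does whether the methoxy change would read the same on the chain of compound 3.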